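A few compounds are considered here, and "the series" means these few. Any claim that something is new, unique, unknown or untested is made for them only; others in the source may bear on it.

In an ADME assay on HeLa cells (Homo sapiens) for cytotoxicity, read by resazurin assay, with a stated time of 2 days (a higher number here means a weaker inhibitor, a lower number a stronger inhibitor), compound 1 `Cc1ccc(/C=C/c2ncc([N+](=O)[O-])n2C)cc1` gives > 100000 nM, which is a limit of the assay and not a number. Its true position is therefore open on one side. Going by the values given here, the only other measured compound, compound 2 `Cn1c([N+](=O)[O-])cnc1/C=C/c1cccc(Cl)c1`, also carries a chloro group and gives a true number of 30200 nM. The next compound, compound 3 `Cn1c([N+](=O)[O-])cnc1/C=C/c1ccc(Cl)cc1`, has chloro in place of methyl on an aromatic carbon, para to a large group: chloro in place of methyl on an aromatic carbon. Among the compounds with values here, with no measured step to draw on, the expectation rests on compound 2 at 30200 nM, and it points to a modest move toward a lower number in this assay. The expected change is an at least 2.5-fold lower number from compound 1 to compound 3 (0.39 log units; beyond the scatter), an estimate that is uncertain since its starting point is only a limit. For compound 3 the estimated value is 40000 nM, with an expected range of 15000 nM to 100000 nM.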

Compound 3, half-maximal inhibitory concentration: 91200 nM
Compound 3: middle estimate off by 2.3-fold (0.36 log units), on the low side, within the range that was stated.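

In this assay compound 3 gives 91200 nM as a true number, so with chloro on this aromatic carbon, para to a large group, the value comes into the measurable range. Compound 1, with methyl in that place, gives > 100000 nM and this is a limit of the assay, not a number. The change reads as an at least 1.0-fold lower number from compound 1 to compound 3 (0.04 log units; that floor lies within the scatter) and can be read only as a floor, so it does not show that chloro in place of methyl moves the number at all, because compound 1 stands at the limit: the limit of > 100000 nM in this assay, at which 1 of the 3 values shown sits.

Going by these compounds, how far the true value of compound 1 lies from that limit stays open, and with it the real size of this change. Also open, on these data alone, is how an amine, a methoxy group or a carboxylic acid on this same carbon would read in this assay against chloro and methyl.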